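Replacing isopropyl with methyl: clearance notes on compound 4

The source may hold more compounds than are shown below. What is called first, only, known or untested is meant among the compounds shown, and "the series" means these compounds.

Values so far in an ADME assay on microsomes from liver (Rattus norvegicus) for metabolic stability (on this read-out higher numbers stand for fast clearance and lower numbers for slow clearance), are these:
- compound 1 `CC(C)c1c(NC(=O)Nc2ccnc(C(F)(F)F)c2)cnc2cc(Cl)nn12` gives < 25 mL.min-1.g-1 as a limit
- compound 2 `CO[C@@H](C)c1c(NC(=O)Nc2cnc(-n3nccn3)c(Cl)c2)cnc2cc(Cl)nn12` gives < 25 mL.min-1.g-1 as a limit
- compound 3 `O=C(Nc1cnc(-n2nccn2)c(Cl)c1)Nc1cnc2cc(Cl)nn2c1C1CCOCC1` gives 25.5 mL.min-1.g-1 as a number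

Compound 1 is known only as a limit and not as a number. Its place on the scale is given by the limit of < 25 mL.min-1.g-1 in this assay, at which 2 of the 3 values shown sit, and nothing finer can be said of it.

Compound 4 `Cc1c(NC(=O)Nc2ccnc(C(F)(F)F)c2)cnc2cc(Cl)nn12` differs from compound 1 by one change, methyl in place of isopropyl on an aromatic carbon with the rest of the structure kept.

Going by the values given here, no measured step involves isopropyl or methyl. The nearest one also exchanges a group on an aromatic carbon, oxan-4-yl in place of 1-methoxyethyl, and it shows an at least 1.0-fold higher number from compound 2 to compound 3 (0.00 log units; that floor lies within the scatter) as its whole size. That step gives only a floor, so it offers no ground for a direction. On that basis, no step beyond the scatter is expected in this assay for the present change. The expected step is a step that the limit leaves unreadable from compound 1 to compound 4 with no direction favoured. A report as a limit is the likeliest outcome, but a number can still be estimated. Compound 4 is expected at 20 mL.min-1.g-1 (expected range 10 mL.min-1.g-1 to 40 mL.min-1.g-1).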

Compound 4, intrinsic clearance in microsomes: < 25 mL.min-1.g-1
Compound 4: a limit, no number (the forecaster's own chance of this, stated with the estimate: 70%); the middle value lies beyond the limit too.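

In this assay compound 1 and compound 4 are both reported only as limits, so no step can be read for methyl in place of isopropyl: the limit of < 25 mL.min-1.g-1 in this assay, at which 3 of the 4 values shown sit. The compounds shown leave open whether this change alters clearance at all, and where compound 1 and compound 4 actually lie on the scale.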